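The source may hold more compounds than are shown below. What is called first, only, known or untested is meant among the compounds shown, and "the series" means these compounds.

Within the data shown here, compound 1 `CC(C)(N)C(=O)N[C@H](COCc1ccccc1)c1nnnn1CCCc1ccccc1` is the more potent of the two compounds measured so far in a functional assay on H4 cells for agonist activity at growth hormone secretagogue receptor type 1 (Homo sapiens), read by FLIPR; on this read-out lower numbers stand for an effect already at smaller amounts and higher numbers for an effect only at larger amounts of compound: compound 1 gives 17 nM. Compound 2 `CC(C)(N)C(=O)N[C@H](COCc1ccccc1)c1nnn(CCCCC#N)n1` gives 1860 nM in this assay, a gap from compound 1 that is well beyond the usual scatter. Compound 3 `COC(=O)CCCn1nnnc1[C@@H](COCc1ccccc1)NC(=O)C(C)(C)N` has not yet been tested. It differs from compound 1 in one place: methoxycarbonyl in place of phenyl on a saturated chain carbon, three bonds along the chain from an aromatic nitrogen. Among the measured compounds shown here, no measured pair shows exactly this change, so the expectation rests on the two numbers at hand, which show that the only departure from compound 1 tried so far moved the number sharply upward. The step from compound 1 to compound 3 is therefore expected to be a rise, an 18-fold higher number from compound 1 to compound 3 (1.25 log units; beyond the scatter), beyond the scatter, partly because compound 2 gives 1860 nM. Compound 3 is estimated to give 300 nM in this assay, with a likely range from 60 nM to 1500 nM.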

Compound 3, half-maximal effective concentration: 55 nM
Compound 3: middle estimate off by 5.5-fold (0.74 log units), on the high side; measured number outside the range, below it.
By their numbers in this assay, from the lowest: compound 1; then compound 3; then compound 2.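

In this assay, putting methoxycarbonyl in place of the phenyl of the 3-phenylpropyl chain gives a 3.2-fold higher number from compound 1 to compound 3 (0.51 log units; beyond the scatter) and so counts as a modest step. Among these compounds, this is the first look at a single change at this place, on a saturated chain carbon, three bonds along the chain from an aromatic nitrogen. The six-membered aromatic ring of carbon can give way to a group with no ring and with hydrogen-bond acceptors, and compound 3 still gives 55 nM with that group in place.

From the compounds shown here alone, whether a carboxylic acid, an amine, an amide or a longer chain ending in methoxycarbonyl would give a lower or a higher number at this place stays open. What lies behind the step also stays open, as no measurement at hand speaks to it.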